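The source may report more compounds than this note shows. Statements on the series, on what has been measured and on what is new or still open speak of the compounds shown alone.

Measured so far in an assay on isolated protein for inhibition of protein deacetylase HDAC6 (Homo sapiens), read by fluorescence; on this read-out higher numbers stand for weaker inhibition and lower numbers for stronger inhibition:

- compound 1, `Cn1cc(-c2ccccc2Oc2ccccc2)c2cc(C(=O)NCCCC(=O)NO)[nH]c2c1=O`: 144 nM
- compound 2, `Cn1cc(-c2ccccc2Oc2ccccc2)c2cc(C(=O)NCCCCCC(=O)NO)[nH]c2c1=O`: 3.4 nM

Going by the values given here, compound 2 gives the lowest of the two numbers in this assay; the only other number is that of compound 1, and the one step recorded between them, a 42-fold lower number from compound 1 to compound 2 (1.63 log units; beyond the scatter), concerns the length of the chain between the amide-type nitrogen and the hydroxamic group, not the hydroxamic group itself.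

Compound 3, `Cn1cc(-c2ccccc2Oc2ccccc2)c2cc(C(=O)NCCCCCC(=O)Nc3ccccc3N)[nH]c2c1=O`, has not yet been measured. It keeps the six-carbon chain of compound 2 and differs in one place: 2-aminophenyl in place of hydroxy on an amide-type nitrogen. Among the compounds with values here, no measured step touches the hydroxamic end of the molecule, so the size of the step from compound 2 to compound 3 cannot be read off from the two numbers above; the step from compound 1 to compound 2 speaks only to chain length.

The expectation for compound 3 is therefore a weakening, with a wide margin: an estimate of 2000 nM in this assay, within 300 nM to 20000 nM, which would mean a step of a 590-fold higher number from compound 2 to compound 3 (2.77 log units; beyond the scatter).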

Compound 3, half-maximal inhibitory concentration: > 500 nM
Compound 3 ended at the assay's limit (the forecaster's own chance of this, stated with the estimate: 15%); the middle value lies beyond the limit too.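

In this assay compound 3 is recorded only as a limit of the assay, not as a number: the limit of > 500 nM in this assay, at which 1 of the 3 values shown sits.

Going by these compounds alone, this is the first reading at the hydroxamic end of the series, and 2-aminophenyl in place of hydroxy on the amide-type nitrogen gives an at least 140-fold higher number from compound 2 to compound 3 (2.16 log units; beyond the scatter), so at this chain length the change is a large loss and the hydroxy cannot be swapped for 2-aminophenyl without cost. The chain gain does not make up for that loss: even with the longer chain the outcome is an at least 3.4-fold higher number from compound 1 to compound 3 (0.54 log units; beyond the scatter), so the (2-aminophenyl)carbamoyl end on the longer chain stands worse than the hydroxycarbamoyl end on the shorter one, and both steps are lower bounds set by the limit.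

The compounds shown leave open how far past the limit compound 3 lies, and whether the loss follows the whole 2-aminophenyl group or its amino group, which an unsubstituted phenyl on the same nitrogen would separate. They also leave open whether the (2-aminophenyl)carbamoyl end responds to chain length as the hydroxycarbamoyl end does, which a longer chain carrying that end would test.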